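The source may hold more compounds than are shown below. What is called first, only, known or untested is meant among the compounds shown, and "the series" means these compounds.

In a functional assay on HepG2 cells (Homo sapiens) for inhibition, read by MTT assay (a lower number here means a stronger inhibitor of growth, a higher number a weaker inhibitor of growth), compound 1 (`COc1cc2oc(-c3cccc(NC(=O)c4cccc(Br)c4)c3)cc(=O)c2c(O)c1OC`) gives 44800 nM. Compound 2 (`COc1cccc(C(=O)Nc2cccc(-c3cc(=O)c4c(O)c(OC)c(OC)cc4o3)c2)c1`) gives > 100000 nM, which is a limit of the assay and not a number. Compound 2 therefore has no exact place on the scale, and the record holds only (the limit of > 100000 nM in this assay, at which 1 of the 2 values shown sits).

The next compound, compound 3 (`COc1ccccc1C(=O)Nc1cccc(-c2cc(=O)c3c(O)c(OC)c(OC)cc3o2)c1`), keeps the same atoms but joins them differently: 2-methoxyphenyl in place of 3-methoxyphenyl on a carbonyl carbon. In words, 2-methoxyphenyl stands in place of 3-methoxyphenyl on a carbonyl carbon.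

Among the measured compounds shown here, only one measured step bears on this change, and it does so indirectly: an at least 2.2-fold higher number from compound 1 to compound 2 (0.34 log units; beyond the scatter), with methoxy in place of bromo on an aromatic carbon. That step exchanges one group for another, whereas compound 3 differs from compound 2 by an isomeric swap, so it offers no direct measure of this change. For the measured compounds named here, with compound 1 at 44800 nM as the only exact value, no step beyond the scatter is expected in this assay. A reading for compound 3 at the same limit as compound 2 is quite possible.

The expected change is an at least 1.1-fold lower number from compound 2 to compound 3 (0.04 log units; that floor lies within the scatter).

For compound 3 the estimated value is 90000 nM, with an expected range from 35000 nM to 200000 nM.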

Compound 3, concentration for 50% growth inhibition: > 100000 nM
Compound 3 was reported as a limit; the forecaster's own chance of this, stated with the estimate: 60%; middle value at least 1.1-fold (0.04 log units) from the limit.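

In this assay, putting 2-methoxyphenyl in place of 3-methoxyphenyl on the carbonyl carbon does not bring the reading back within the range of the assay: compound 3 gives > 100000 nM, which is a limit of the assay and not a number. The step for this isomeric swap cannot be read, because both methoxyphenyl compounds stand at the same limit: the limit of > 100000 nM in this assay, at which 2 of the 3 values shown sit.

What is new is the second measured replacement of 3-bromophenyl: 2-methoxyphenyl on the carbonyl carbon gives an at least 2.2-fold higher number from compound 1 to compound 3 (0.34 log units; beyond the scatter), in the same direction as the earlier change to 3-methoxyphenyl, so both methoxyphenyl isomers read as weaker inhibitors of growth than the bromo compound, and none of the three compounds goes against this.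

On these data alone, how far either isomer lies past the limit remains open, so 2-methoxyphenyl and 3-methoxyphenyl cannot be ranked against each other. Also open, as far as these compounds go, is whether growth inhibition on this carbonyl carbon would hold, improve or vanish with 2-bromophenyl, 4-bromophenyl or an aminophenyl group there.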